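Pyridin-2-yl in Place of 2-Aminophenyl on the Sulfonyl

This account rests on a few compounds, and the source may have more. Where it says the series, first, only, none or still open, it means among the compounds named here.

Three measured compounds share one core and differ only in the ring on the sulfonyl sulfur. In a functional assay (trachea) for antagonist activity, with Cavia porcellus as the target (on this read-out higher numbers stand for higher potency (the scale is a negative logarithm) and lower numbers for lower potency), compound 1 `COc1cc(C(=O)NS(=O)(=O)c2ccccc2Cl)ccc1Cn1ccc2ccc(NC(=O)CC3CCCC3)cc21` gives 9.8, compound 2 `COc1cc(C(=O)NS(=O)(=O)c2ccccc2C)ccc1Cn1ccc2ccc(NC(=O)CC3CCCC3)cc21` gives 9.9, and compound 3 `COc1cc(C(=O)NS(=O)(=O)c2ccccc2N)ccc1Cn1ccc2ccc(NC(=O)CC3CCCC3)cc21` gives 9.9. The steps of a number 0.10 log units higher from compound 1 to compound 2 (within the scatter), a number 0.10 log units higher from compound 1 to compound 3 (within the scatter) and no change at the digits printed from compound 2 to compound 3 (within the scatter) all lie within the scatter, so compound 3 stands level with compound 2 and close to compound 1. Compound 4 `COc1cc(C(=O)NS(=O)(=O)c2ccccn2)ccc1Cn1ccc2ccc(NC(=O)CC3CCCC3)cc21` carries the change (pyridin-2-yl in place of 2-aminophenyl on a sulfonyl sulfur). Among the measured compounds shown here, no measured step exchanges the whole ring; the three steps bear on it only by showing that three different groups at this place gave numbers within the scatter of one another. A shift of a number 0.40 log units lower from compound 3 to compound 4 (beyond the scatter) in this assay is expected, without a confident direction. Compound 4 is therefore estimated at 9.5, between 8.8 and 10.1.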

Compound 4, negative logarithm of the antagonist equilibrium constant: 8.9
For compound 4 the middle estimate is 0.60 log units above the measured one; measured number inside the range.
By their numbers in this assay, from the lowest: compound 4; then compounds 1, 2 and 3 (each within the scatter of the next).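

Exchanges among 2-chlorophenyl, 2-methylphenyl and 2-aminophenyl had stayed within the scatter, whereas pyridin-2-yl on the sulfonyl sulfur in this assay brings the steps of a number 1.00 log units lower from compound 3 to compound 4 (beyond the scatter) and a number 1.00 log units lower from compound 2 to compound 4 (beyond the scatter) and a number 0.90 log units lower from compound 1 to compound 4 (beyond the scatter) with it. This place on the sulfonyl sulfur is therefore not indifferent to the group it carries, although three different substituted phenyl groups gave numbers within the scatter of one another. Nothing available accounts for the loss. Open, going by these compounds, is whether unsubstituted phenyl or pyridin-3-yl would stand with compound 4 or with the three phenyl compounds.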